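The source may report more compounds than this note shows. Statements on the series, on what has been measured and on what is new or still open speak of the compounds shown alone.

Compound 1 (`CC1=CC[C@H](C(C)(C)NC(=S)N/N=C/c2ccc(O)cc2)CC1`) gives > 100000 nM in a functional assay on HT-29 cells (Homo sapiens) for inhibition, read by sulforhodamine B assay, with a stated time of 48 h (a higher number here means a weaker inhibitor of growth, a lower number a stronger inhibitor of growth), which is a limit of the assay rather than a number. Compound 2 (`CC1=CC[C@H](C(C)(C)NC(=S)N/N=C/c2ccccc2O)CC1`) gives 10900 nM in this assay. Compound 3 (`CC1=CC[C@H](C(C)(C)NC(=S)N/N=C/c2ccccc2[N+](=O)[O-])CC1`) gives 7900 nM in this assay.

Of the two values that are actual numbers, compound 2 has the higher one; its nearest neighbour is compound 3, and the gap between them, a 1.4-fold lower number from compound 2 to compound 3 (0.14 log units; within the scatter), lies within the usual scatter, so the two cannot be told apart. The change that leads to compound 4 (`CC1=CC[C@H](C(C)(C)NC(=S)N/N=C/c2cccs2)CC1`) is thiophen-2-yl in place of 2-hydroxyphenyl on a carbon with a double bond to nitrogen. Going by the values given here, two measured steps bear on this change. The first, an at least 9.1-fold lower number from compound 1 to compound 2 (0.96 log units; beyond the scatter), shows that the position of the hydroxy group on the ring matters, though this step rests on a limit (the limit of > 100000 nM in this assay, at which 1 of the 3 values shown sits). The second, a 1.4-fold lower number from compound 2 to compound 3 (0.14 log units; within the scatter), shows that swapping the hydroxy group for nitro left the number essentially where it was. Compound 4 loses the hydroxy group altogether and takes a smaller aromatic ring in its place; of the two precedents, the second is the closer one, and no step beyond the scatter is expected in this assay. Compound 4 is therefore expected to give about 10000 nM, with a likely range from 3000 nM to 40000 nM. That amounts to an expected step of a 1.1-fold lower number from compound 2 to compound 4 (0.04 log units; within the scatter).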

Compound 4, concentration for 50% growth inhibition: 17800 nM
For compound 4 the middle estimate is 1.8-fold (0.25 log units) below the measured one, and the stated range covers the measured number.
By their numbers in this assay, from the lowest: compounds 3, 2 and 4 (each within the scatter of the next, the first and the last beyond it). At a limit, above all of these: compound 1.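

The thiophen-2-yl group on the carbon with a double bond to nitrogen gives a 1.6-fold higher number from compound 2 to compound 4 (0.21 log units; within the scatter), so here the six-membered aromatic ring of carbon only and its hydroxy group can both be replaced by a five-membered aromatic ring containing sulfur, with no difference that can be told from the scatter in this assay. The other new step, an at least 5.6-fold lower number from compound 1 to compound 4 (0.74 log units; beyond the scatter), places compound 4 with compound 2 and apart from compound 1, which makes the 4-hydroxyphenyl group the one that goes against the otherwise similar numbers among the four compounds. The value of compound 1 is a limit and not a number, so this step gives only a minimum size: the limit of > 100000 nM in this assay, at which 1 of the 4 values shown sits.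

The compounds shown do not separate the loss of the hydroxy group from the change of ring, a question that plain phenyl or a thiophen-2-yl ring carrying a hydroxy group would address. They also leave open whether this carbon needs an aromatic ring at all, as cyclohexyl or a short alkyl chain would show, and how a ring containing nitrogen, such as pyridin-2-yl, or a ring carrying an amine or a carboxylic acid would behave.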